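The source may report more compounds than this note shows. Statements on the series, on what has been measured and on what is new or still open speak of the compounds shown alone.

Measured in a functional assay on HeLa S3 cells (Homo sapiens) for antiproliferative activity, read by XTT assay, with a stated time of 72 h; a lower number here means a stronger inhibitor, a higher number a weaker inhibitor:
Compound 1, `O=c1[nH]cnc2c1c(-c1ccoc1)cn2[C@@H]1O[C@H](CO)[C@@H](O)[C@H]1O`: compound 1 gives > 20000 nM, which is a limit of this assay.
Compound 2, `COc1ncnc2c1c(-c1ccoc1)cn2[C@@H]1O[C@H](CO)[C@@H](O)[C@H]1O`: compound 2 gives 1790 nM.
Compound 3, `O=c1[nH]cnc2c1c(-c1cccs1)cn2[C@@H]1O[C@H](CO)[C@@H](O)[C@H]1O`: compound 3 gives > 20000 nM, also a limit.

Compound 4, `COc1ncnc2c1c(-c1cccs1)cn2[C@@H]1O[C@H](CO)[C@@H](O)[C@H]1O`, is not yet measured. How the cores of compound 1 and compound 2 differ is not broken down here. From compound 1 to compound 3 the change is thiophen-2-yl in place of furan-3-yl on an aromatic carbon; the step is a step that the two limits leave unreadable from compound 1 to compound 3, unreadable in size, as the limit of > 20000 nM in this assay, at which 2 of the 3 values shown sit, shows. Within the data shown here, compound 2 carries the only plain number. From compound 2 to compound 4 the change is thiophen-2-yl in place of furan-3-yl on an aromatic carbon, the same change at the same place. The earlier step gives no size to lean on, so the step from compound 2 to compound 4 is expected to be modest, a 1.4-fold higher number from compound 2 to compound 4 (0.15 log units; within the scatter). Compound 4 is estimated at 2500 nM, within 800 nM to 8000 nM.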

Compound 4, half-maximal inhibitory concentration: 1760 nM
Beside the measured number, compound 4's estimate is 1.4-fold (0.15 log units) above it, and the stated range covers the measured number.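

In this assay, thiophen-2-yl in place of furan-3-yl on an aromatic carbon gives a 1.0-fold lower number from compound 2 to compound 4 (0.01 log units; within the scatter). The same change on the core of compound 1 cannot be read in size, because both compounds of that pair sit at a limit: the limit of > 20000 nM in this assay, at which 2 of the 4 values shown sit. The series therefore holds one readable case of this change, on one core, and does not show that the step carries from one core to the other.

Open, from the compounds shown here alone, is how an amine or a longer alkyl chain would read at this place in this assay. Also open, going by these compounds, is whether any group at this place gives a plain number on the core of compound 1.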